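Quinolin-6-yl replaces 1H-indol-6-yl on the amine nitrogen

The compounds below may be only part of what the source reports. "The series", "measured", "known", "first", "only" and "open" are said of these compounds alone.

In a functional assay on MCF7 cells (Homo sapiens) for cytotoxicity, read by MTT assay, with a stated time of 48 h (a lower number here means a stronger inhibitor, a higher number a weaker inhibitor), compound 3 `O=C(/C=C\Nc1ccc2cc[nH]c2c1)c1c(-c2ccc(Cl)cc2)nc2ccccn12` stands at 9600 nM on the scale. Compound 1 `COc1ccc(-c2nc3ccccn3c2C(=O)/C=C\Nc2ccc3ncccc3c2)cc1` stands at 11600 nM and compound 2 `COc1cc(N/C=C\C(=O)c2c(-c3ccc(Cl)cc3)nc3ccccn23)cc(OC)c1` at 13600 nM on the same scale, so all three lie within the usual scatter of repeated measurements and no ranking can be drawn among them.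

Compound 4 `O=C(/C=C\Nc1ccc2ncccc2c1)c1c(-c2ccc(Cl)cc2)nc2ccccn12` has not been measured yet. It differs from compound 3 in one group on an amine nitrogen: quinolin-6-yl in place of 1H-indol-6-yl on an amine nitrogen so that quinolin-6-yl stands in place of 1H-indol-6-yl there.

Going by the values given here, the one measured step at this place is a 1.4-fold lower number from compound 2 to compound 3 (0.15 log units; within the scatter) and it brought in 1H-indol-6-yl in place of 3,5-dimethoxyphenyl without leaving the scatter. Compound 1 already carries quinolin-6-yl on an amine nitrogen, although it differs from compound 4 elsewhere in the molecule. That gives only two clues, but with compound 1 at 11600 nM and a step that small, no shift beyond the scatter is expected in this assay for this exchange either.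

The estimated step is a 1.1-fold higher number from compound 3 to compound 4 (0.06 log units; within the scatter) and it is expected to stay within the scatter. For compound 4 the expected value is 11000 nM with an estimated range from 6000 nM to 20000 nM for now.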

Compound 4, half-maximal inhibitory concentration: 22800 nM
Compound 4: the middle estimate sits 2.1-fold (0.32 log units) below what was measured; the whole stated range lies below it.
By their numbers in this assay, from the lowest: compounds 3, 1, 2 and 4 (each within the scatter of the next, the first and the last beyond it).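

In this assay, the group on the amine nitrogen now shows a measurable effect: quinolin-6-yl in place of 1H-indol-6-yl gives a 2.4-fold higher number from compound 3 to compound 4 (0.38 log units; beyond the scatter) and so leaves the scatter, though only modestly. Going by these compounds alone, this is the only step at this position that does so, since quinolin-6-yl in place of 3,5-dimethoxyphenyl gives a 1.7-fold higher number from compound 2 to compound 4 (0.22 log units; within the scatter) and stays within the scatter. Away from the amine, chloro in place of methoxy on an aromatic carbon gives a 2.0-fold higher number from compound 1 to compound 4 (0.29 log units; within the scatter) and also stays within the scatter, so this change shows no clear effect in the one pair available.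

The exchange at the amine nitrogen replaces a hydrogen-bond donor with a hydrogen-bond acceptor and a five-membered ring with a six-membered one, and no measurement here links the step to either difference. From the compounds shown here alone, it also remains open how a simple phenyl or a pyridin-3-yl group on the amine nitrogen would compare, and whether a single ring of this kind would stand closer to compound 3 or to compound 4.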